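The source may report more compounds than this note shows. Statements on the series, on what has been measured and on what is new or still open speak of the compounds shown alone.

Measured compounds:
compound 1, `CC(=O)OC/C(=C\c1ccc(Cl)cc1Cl)C(=O)c1ccccc1`, 14000 nM
compound 2, `O=C(OC/C(=C\c1ccc(Cl)cc1Cl)C(=O)c1ccccc1)c1ccccc1`, 17000 nM
compound 3, `O=C(OC/C(=C\c1ccccc1[N+](=O)[O-])C(=O)c1ccccc1)c1ccccc1`, 18000 nM

All three were tested in a functional assay on WiDr cells (Homo sapiens) for inhibition, read by sulforhodamine B assay, with a stated time of 48 h; on this read-out lower numbers stand for stronger inhibition of growth and higher numbers for weaker inhibition of growth. Compound 2 stands second highest of the three numbers; its nearest neighbour is compound 3 and its furthest is compound 1, and both of those gaps lie within the scatter. The two measured steps are small: a 1.2-fold higher number from compound 1 to compound 2 (0.08 log units; within the scatter), and a 1.1-fold higher number from compound 2 to compound 3 (0.02 log units; within the scatter). Neither the exchange on the carbonyl carbon nor the exchange of the aryl group on the double-bonded chain carbon moved the read-out beyond what repeated measurement would show.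

Compound 4, `O=C(OC/C(=C/c1ccc(Cl)cc1Cl)C(=O)c1ccccc1)c1ccccc1`, is not yet measured. Compared with compound 2, (the two compounds have the same atoms and bonds and differ only in configuration as drawn: 1 of 1 stereo elements differ; a double bond is drawn E in compound 2 and Z in compound 4). Going by the values given here, none of the measured steps concerns the geometry of this double bond, so there is no direct precedent for the change. Among the compounds with values here, the only guide is that the shared core has so far tolerated both changes tried without any step beyond the scatter. Compound 4 is therefore expected to give about 17000 nM in this assay, with a range from 6000 nM to 50000 nM. From the compounds shown here alone, the expected step is no change at the digits printed from compound 2 to compound 4 (within the scatter), with the range kept wide since the geometry change is untested here.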

Compound 4, concentration for 50% growth inhibition: 8700 nM
Beside the measured number, compound 4's estimate is 2.0-fold (0.29 log units) above it; the measured number falls inside the stated range.
By their numbers in this assay, from the lowest: compounds 4, 1, 2 and 3 (each within the scatter of the next, the first and the last beyond it).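

Until this point, the measured steps in this assay had only exchanged groups on the shared core, whereas this pair tests the geometry of the double bond itself, with nothing leaving and nothing entering. The result is a 2.0-fold lower number from compound 2 to compound 4 (0.29 log units; within the scatter), so the read-out does not separate the E and Z forms drawn here, and this double bond joins the two group exchanges as a third change that stays inside the scatter. The comparison is also a clean one, since only a single feature can lie behind any gap between the two numbers: the fact that compounds 2 and 4 differ only in the configuration as drawn

The compounds shown leave open whether the same holds for the Z form with the 2-nitrophenyl group on the double-bonded chain carbon, or with methyl in place of phenyl on the carbonyl carbon, since the Z geometry appears here only with 2,4-dichlorophenyl and phenyl at those two places. They also leave open whether a carboxylic acid or an amine in place of the phenyl on the carbonyl carbon would move the number beyond the scatter in this assay, in either geometry.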